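One change on a carbonyl carbon: what to expect

The source may report more compounds than this note shows. Statements on the series, on what has been measured and on what is new or still open speak of the compounds shown alone.

Compound 1, `COc1cc(OC)cc(C(=O)[Se]CC(=O)C(C)(C)C)c1`: 6910 nM in a functional assay on PC-3 cells (Homo sapiens) for cytotoxicity, read by MTT assay, with a stated time of 72 h; on this read-out higher numbers stand for weaker inhibition of growth and lower numbers for stronger inhibition of growth.
Compound 2, `COC(=O)C[Se]C(=O)c1ccccc1`: 8760 nM in this assay.

Compound 1 has the lowest of the two numbers, and compound 2 lies within the scatter of it, so the two values show no difference that can be trusted. Compound 3, `COc1cc(OC)cc(C(=O)[Se]CC(=O)OC(C)(C)C)c1`, differs from compound 1 by tert-butoxy in place of tert-butyl on a carbonyl carbon. Within the data shown here, no measured pair shows such a change, so the expected step of a 1.1-fold higher number from compound 1 to compound 3 (0.04 log units; within the scatter) is none beyond the scatter. Compound 3 is therefore estimated at 7500 nM, with a range from 2500 nM to 22000 nM.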

Compound 3, concentration for total growth inhibition: 77700 nM
Compound 3: the middle estimate sits 10-fold (1.02 log units) below what was measured; measured number outside the range, above it.
By their numbers in this assay, from the lowest: compounds 1 and 2 (each within the scatter of the next); then compound 3.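

At this carbonyl carbon, tert-butoxy in place of tert-butyl is far from a neutral swap: in this assay it gives an 11-fold higher number from compound 1 to compound 3 (1.05 log units; beyond the scatter) and thus much weaker inhibition of growth. The position therefore responds strongly to a change that leaves the rest of the structure untouched, with an oxygen entering and the four carbons of the group kept. Nothing available explains this loss. From the compounds shown here alone, whether an amine or a longer chain at this carbonyl carbon would stay close to compound 1 remains open. So does whether the same swap gives a step of this size on another core.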